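Side-chain changes at the amide carbonyl: binding notes

The compounds below may be only part of what the source reports. "The series", "measured", "known", "first", "only" and "open" are said of these compounds alone.

compound 1 `CC(C)C[C@H](N)c1cc(C(F)(F)F)ccc1N1CCN(C(=O)C(C)Cc2ccc(Cl)c(Cl)c2)CC1`: 120 nM; 1600 nM (2 entries)
compound 2 `COc1cc(CC(C)C(=O)N2CCN(c3ccc(C(F)(F)F)cc3[C@@H](N)CC(C)C)CC2)ccc1Cl`: 230 nM
compound 3 `CC(C)C[C@H](N)c1cc(C(F)(F)F)ccc1N1CCN(C(=O)C(C)Cc2ccc(Cl)cc2)CC1`: 47 nM

In an assay on HEK293 cells for displacement of a labelled ligand from Melanocortin receptor 4 (Homo sapiens) (on this read-out higher numbers stand for weaker inhibition and lower numbers for stronger inhibition), compound 3 gives the lowest of the two single numbers; the nearest is compound 2, and the step of a 4.9-fold lower number from compound 2 to compound 3 (0.69 log units; beyond the scatter) is hydrogen in place of methoxy on an aromatic carbon. Compound 1 has two entries that spread widely, (the several entries of compound 1 in this assay, 120 nM; 1600 nM (2 entries)), and so gives no single number to rank against.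

Compound 4 `CC(C)C[C@H](N)c1cc(C(F)(F)F)ccc1N1CCN(C(=O)CSc2ccc(Cl)cc2Cl)CC1` differs from compound 3 by ((2,4-dichlorophenyl)sulfanyl)methyl in place of 1-(4-chlorobenzyl)ethyl on a carbonyl carbon. For the measured compounds named here, no measured step covers this exchange: the one measured step, a 4.9-fold lower number from compound 2 to compound 3 (0.69 log units; beyond the scatter), changes the aromatic substitution and not the group on the carbonyl carbon, while the spread of compound 1, (the several entries of compound 1 in this assay, 120 nM; 1600 nM (2 entries)), shows how uncertain values in this region are. A modest move to a higher number is therefore expected, a 4.3-fold higher number from compound 3 to compound 4 (0.63 log units; beyond the scatter). Compound 4 is expected at 200 nM, within 50 nM to 800 nM.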

Compound 4, inhibition constant: 1500 nM
The estimate for compound 4 lay 7.5-fold (0.88 log units) below the measured number, and the stated range ends below it.
By their numbers in this assay, from the lowest: compound 3; then compound 2; then compound 4.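

Exchanging 1-(4-chlorobenzyl)ethyl for ((2,4-dichlorophenyl)sulfanyl)methyl on the carbonyl carbon gives a 32-fold higher number from compound 3 to compound 4 (1.50 log units; beyond the scatter), so this position shows a large step where the earlier aromatic change showed a modest one. The same exchange from the methoxy-bearing side chain gives a 6.5-fold higher number from compound 2 to compound 4 (0.81 log units; beyond the scatter), so in this assay both 1-substituted ethyl groups give lower numbers than the sulfanyl group.

Steps to compound 1 cannot be read: the several entries of compound 1 in this assay, 120 nM; 1600 nM (2 entries) The exchange alters sulfur, chlorine count and chain together, leaving open what a methylene in place of sulfur or a single 4-chloro on the sulfanyl-linked ring would give.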